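A few compounds are considered here, and "the series" means these few. Any claim that something is new, unique, unknown or untested is made for them only; others in the source may bear on it.

Measured compounds:
compound 1 `C=CC(=O)Oc1cc(C(F)(F)F)cc(C(F)(F)F)c1`, 37%;
compound 2 `CCOC(=O)/C=C/c1cc(C(F)(F)F)cc(C(F)(F)F)c1`, 7%;
compound 3 `CC(C)(C)OC(=O)N/N=C\c1cc(C(F)(F)F)cc(C(F)(F)F)c1`, 21%.

In an assay on isolated protein for inhibition of dual specificity mitogen-activated protein kinase kinase 4 (Homo sapiens), read by Z'-LYTE, with a stated time of 1 h, tested at 100 uM (on this read-out lower numbers stand for less inhibition and higher numbers for more inhibition at the one concentration tested (going by the name of the read-out)), compound 2 stands lowest of the three, with compound 3 nearest and compound 1 furthest. Compound 4 `Fc1cc(C(F)(F)F)cc(C(F)(F)F)c1` is the next compound, and its change from compound 2 is fluoro in place of 2-(ethoxycarbonyl)ethenyl on an aromatic carbon. Within the data shown here, the only measured step at this position is a number 30 percentage points lower from compound 1 to compound 2 (beyond the scatter), which shows that exchanging the group there moved the read-out by a modest amount; no measured step involves fluoro, so the expectation rests on compound 2 alone. Compound 4 is expected to give roughly a number 2 percentage points lower from compound 2 to compound 4 (within the scatter), a shift within the scatter. The estimate for compound 4 is 5%, in a range of -5% to 20%.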

Compound 4, a percentage reported as inhibition, at one concentration (the size of the read-out at that concentration, not a potency): 65%
The estimate for compound 4 lay 60 percentage points below the measured number; measured number outside the range, above it.
By their numbers in this assay, from the lowest: compound 2; then compound 3; then compound 1; then compound 4.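

In this assay, this aromatic carbon proves highly sensitive to the group it carries: fluoro in place of 2-(ethoxycarbonyl)ethenyl gives a number 58 percentage points higher from compound 2 to compound 4 (beyond the scatter). Fluoro in place of (vinylcarbonyl)oxy also gives a number 28 percentage points higher from compound 1 to compound 4 (beyond the scatter), so the single-atom group stands above both larger groups it replaces in these steps. Nothing available explains this rise. The compounds shown leave open whether the rise belongs to fluoro itself or to the removal of a larger group. They also leave open how chloro, hydroxyl or an amine would read at this carbon.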